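Removing the chloro from compound 1

A few compounds are considered here, and "the series" means these few. Any claim that something is new, unique, unknown or untested is made for them only; others in the source may bear on it.

Measured in a functional assay on SR cells (Homo sapiens) for antiproliferative activity; on this read-out higher numbers stand for weaker inhibition of growth and lower numbers for stronger inhibition of growth
compound 1 `COc1cc(-n2cc(-c3ccc(Cl)cc3)[nH]c2=O)cc(OC)c1OC` gives > 100000 nM as a limit
compound 2 `O=c1[nH]c(-c2ccc(Cl)c(Cl)c2)cn1-c1ccc(Cl)cc1` gives 5010 nM as a number

Compound 1 reports the limit of > 100000 nM in this assay, at which 1 of the 2 values shown sits, and so carries no number of its own. Within the data shown here, compound 2 holds the only actual number, 5010 nM in this assay, and no measured pair differs in one place.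

Compound 3 `COc1cc(-n2cc(-c3ccccc3)[nH]c2=O)cc(OC)c1OC` is the core of compound 1 with hydrogen in place of chloro on an aromatic carbon, a change from 4-chlorophenyl to phenyl on a six-membered aromatic ring of carbon only, para to a large group. Among the measured compounds shown here, no measured step gives the size of this change, so any expectation here is a loose one. Only a small move is expected in this assay, and a second limit is about as likely as a number. The estimated change is an at least 2.0-fold lower number from compound 1 to compound 3 (0.30 log units; that floor lies within the scatter) as a modest expected move toward stronger inhibition of growth. The expected value for compound 3 is 50000 nM within an estimated range from 10000 nM to 100000 nM in this series.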

Compound 3, concentration for 50% growth inhibition: > 100000 nM
Compound 3 was reported as a limit; the forecaster's own chance of this, stated with the estimate: 55%; middle value at least 2.0-fold (0.30 log units) away from the limit.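

In this assay, compound 1 and compound 3 are both reported only as limits, so no step can be read for hydrogen in place of chloro on an aromatic carbon: the limit of > 100000 nM in this assay, at which 2 of the 3 values shown sit. The compounds shown leave open whether the change from 4-chlorophenyl to phenyl has any effect on growth inhibition in this assay.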